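Trifluoromethyl on the benzyl arm of a propargylamine core

The compounds below may be only part of what the source reports. "The series", "measured", "known", "first", "only" and "open" are said of these compounds alone.

Compound 1 `C#CCNC1CCc2c(SCc3ccccc3)cccc21` carries a propargylamine on the shared core with an unsubstituted benzylthio arm. In an ADME assay on isolated protein for inhibition of Amine oxidase [flavin-containing] B (Homo sapiens) (a higher number here means a weaker inhibitor, a lower number a stronger inhibitor), compound 1 gives "not active" (no number reported), so no single number places it on the scale. Going by the values given here, the only numbered neighbour is compound 2 `C#CCNC1CCc2c(SCc3ccc(OC)cc3)cccc21`, which in this assay gives 3960 nM; no step is reported between compound 1 and compound 2, and their two results can only be set side by side: one without a number, one with a value in the low micromolar range.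

Compound 3 `C#CCNC1CCc2c(SCc3cccc(C(F)(F)F)c3)cccc21` differs from compound 1 by trifluoromethyl in place of hydrogen on an aromatic carbon. With compound 1 lacking a number, the size of this step in this assay cannot be stated; a substituent on the benzyl ring did give a number for compound 2, but compound 3 may just as well return no number. The expectation for compound 3 in this assay is a half-maximal inhibitory concentration near 6000 nM, within a range of 1500 nM to 30000 nM, with a real chance of no number at all.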

Compound 3, half-maximal inhibitory concentration: 7710 nM
Estimate against measurement, compound 3: 1.3-fold (0.11 log units) below, within the range that was stated.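

In this assay compound 1 gives "not active" (no number reported) and compound 3 gives 7710 nM, so no step can be read between these two compounds. Nothing further is available that bears on this result. The compounds shown leave open how much trifluoromethyl in place of hydrogen on the aromatic carbon changes inhibition.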